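A few compounds are considered here, and "the series" means these few. Any claim that something is new, unique, unknown or untested is made for them only; others in the source may bear on it.

Measured in a functional assay on NMC-797 cells (Homo sapiens) for antiproliferative activity, with a stated time of 48 h; a lower number here means a stronger inhibitor, a higher number a weaker inhibitor:
Compound 1 `O=C1C=C[C@]2(C[C@@H](c3c(F)c(F)c(F)c(F)c3F)O[C@@H](c3c(F)c(F)c(F)c(F)c3F)O2)O1`: 570 nM
Compound 2 `O=C1C=C[C@]2(C[C@@H](c3cccc([N+](=O)[O-])c3)O[C@@H](c3ccccc3)O2)O1`: 160 nM

Of these two, compound 2 has the lower number at 160 nM, and the gap to compound 1 lies beyond the usual scatter. Compound 3 `O=C1C=C[C@]2(C[C@@H](c3ccccc3)O[C@@H](c3ccccc3)O2)O1` has not yet been measured in this assay. It differs from compound 2 in one place, with hydrogen in place of nitro on an aromatic carbon. Within the data shown here, no two measured compounds differ in only one place, so no measurement shows the size of such a change. With compound 1 at 570 nM as the only other reference, a number in the same general region seems a cautious expectation. The expected step of a 1.9-fold higher number from compound 2 to compound 3 (0.27 log units; within the scatter) is modest, towards a somewhat weaker inhibitor, and it may not clear the scatter. Compound 3 is estimated at 300 nM, with an expected range of 100 nM to 900 nM.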

Compound 3, half-maximal inhibitory concentration: 900 nM
Compound 3: the middle estimate sits 3.0-fold (0.48 log units) below what was measured, within the range that was stated.
By their numbers in this assay, from the lowest: compound 2; then compounds 1 and 3 (each within the scatter of the next).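

Replacing the nitro group with hydrogen on this aromatic carbon gives a 5.6-fold higher number from compound 2 to compound 3 (0.75 log units; beyond the scatter) in this assay and provides the first direct measure of what a change at this one place is worth. The step lies beyond the scatter, so in this pair the compound carrying the nitro group is the stronger inhibitor, and hydrogen does not serve as an equal replacement at this position. Nothing measured here accounts for the size or direction of this step.

From the compounds shown here alone, it remains open whether this advantage is specific to nitro or would also appear with another group on the same carbon, such as an amine, a nitrile or a carboxylic acid. The compounds shown also cannot say how a nitro group would fare on another carbon of that ring.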